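The source may report more compounds than this note shows. Statements on the series, on what has been measured and on what is new or still open speak of the compounds shown alone.

Measured in a functional assay on HepG2 cells (Homo sapiens) for inhibition, read by MTT assay, with a stated time of 48 h; on this read-out lower numbers stand for stronger inhibition of growth and higher numbers for weaker inhibition of growth:
compound 1 `Cc1ccc(C(=O)N2N=C(c3ccccc3)CC2c2cn(C)c3ccccc23)cn1` gives 1220 nM
compound 2 `Cn1cc(C2CC(c3ccc(Cl)cc3)=NN2C(=O)c2cccnc2)c2cc(Br)ccc21` gives 5800 nM
compound 3 `Cn1cc(C2CC(c3ccc(Br)cc3)=NN2C(=O)c2cccnc2)c2cc(Br)ccc21` gives 6910 nM

Compound 3 stands level with compound 2: the step is a 1.2-fold higher number from compound 2 to compound 3 (0.08 log units; within the scatter) and the two cannot be told apart. Compound 3 (6910 nM) carries a clearly higher number than compound 1 (1220 nM), a gap beyond the scatter, although these two differ in more than one place.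

Compound 4 `COc1cc(C2=NN(C(=O)c3cccnc3)C(c3cn(C)c4ccc(Br)cc34)C2)cc(OC)c1OC` has not yet been measured. It keeps the rest of compound 3 and changes one group: 3,4,5-trimethoxyphenyl in place of 4-bromophenyl on a carbon with a double bond to nitrogen. In words, this is 3,4,5-trimethoxyphenyl in place of 4-bromophenyl on a carbon with a double bond to nitrogen.

Among the compounds with values here, only one measured step touches this group, the swap of bromo in place of chloro on an aromatic carbon, and it was small (a 1.2-fold higher number from compound 2 to compound 3 (0.08 log units; within the scatter)). Within the data shown here, that step says little here, as no measured compound carries a 3,4,5-trimethoxyphenyl group. No step beyond the scatter is therefore expected in this assay, though with low confidence. The expected change is a 1.7-fold lower number from compound 3 to compound 4 (0.24 log units; within the scatter), which stays within the scatter. For compound 4 the estimated value is 4000 nM, with an expected range from 1000 nM to 12000 nM.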

Compound 4, concentration for 50% growth inhibition: > 10000 nM
Compound 4 was reported as a limit (the forecaster's own chance of this, stated with the estimate: 5%); at least 2.5-fold (0.39 log units) between middle value and limit.
By their numbers in this assay, from the lowest: compound 1; then compounds 2 and 3 (each within the scatter of the next). At a limit, above all of these: compound 4.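

In this assay compound 4 gives > 10000 nM, which is a limit of the assay and not a number: the limit of > 10000 nM in this assay, at which 1 of the 4 values shown sits.

Placing 3,4,5-trimethoxyphenyl on the carbon with a double bond to nitrogen gives an at least 1.4-fold higher number from compound 3 to compound 4 (0.16 log units; that floor lies within the scatter), and the same group gives an at least 1.7-fold higher number from compound 2 to compound 4 (0.23 log units; that floor lies within the scatter) when it replaces 4-chlorophenyl. The earlier compounds shown here showed only an exchange of one halogen for another at this position, whereas this result shows that replacing the whole 4-halophenyl group with a larger one carrying three methoxy groups brings no lower number, although both floors lie within the scatter and so do not establish a loss.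

The compounds shown leave open how a single methoxy group, an amine or a carboxylic acid on this phenyl ring would read, and how far the true value of compound 4 lies from those of compound 2 and compound 3. Compound 1 differs from compound 2 and compound 3 in more than one place, so they do not tell which of those differences goes with its lower number.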